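The source may hold more compounds than are shown below. What is called first, only, known or untested is meant among the compounds shown, and "the series" means these compounds.

Within the data shown here, compound 2 `CC(=O)C[C@H]1O[C@@H](On2cc(CN3C(=O)/C(=N\Nc4ccc(C#N)cc4)c4ccccc43)nn2)[C@H](OC(C)=O)[C@@H](OC(C)=O)[C@H]1OC(C)=O` is one of only two compounds measured in an ADME assay on Vero cells (Chlorocebus sabaeus) for cytotoxicity, read by fluorescence and resazurin assay, with a stated time of 3 days (a higher number here means that more compound is tolerated, a lower number that less compound is tolerated), where compound 2 gives 75500 nM. Among the measured compounds shown here, the other, compound 1 `CC(=O)C[C@H]1O[C@@H](On2cc(CN3C(=O)/C(=N\Nc4ccccc4)c4ccccc43)nn2)[C@H](OC(C)=O)[C@@H](OC(C)=O)[C@H]1OC(C)=O`, gives 65200 nM in this assay, and the single measured step, a 1.2-fold higher number from compound 1 to compound 2 (0.06 log units; within the scatter), places the two numbers within the scatter of each other, so neither can be called more tolerated than the other.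

Compound 3 `CC(=O)C[C@H]1O[C@@H](On2cc(CN3C(=O)/C(=N\Nc4ccc(F)cc4)c4ccccc43)nn2)[C@H](OC(C)=O)[C@@H](OC(C)=O)[C@H]1OC(C)=O` is obtained from compound 2 by a change at the same position that distinguished compound 1 from compound 2: fluoro in place of cyano on an aromatic carbon.

For the measured compounds named here, the only step that bears on this change is a 1.2-fold higher number from compound 1 to compound 2 (0.06 log units; within the scatter), in which putting cyano onto that aromatic carbon altered nothing beyond the scatter. Replacing that cyano with fluoro is therefore expected to leave the number essentially unchanged, as a 1.1-fold lower number from compound 2 to compound 3 (0.03 log units; within the scatter). The estimate for compound 3 in this assay is 70000 nM, with an expected range from 35000 nM to 140000 nM.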

Compound 3, half-maximal cytotoxic concentration: 78600 nM
Estimate against measurement, compound 3: 1.1-fold (0.05 log units) below; low and high end bracket the measured number.
By their numbers in this assay, from the lowest: compounds 1, 2 and 3 (each within the scatter of the next).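

In this assay, the step of a 1.0-fold higher number from compound 2 to compound 3 (0.02 log units; within the scatter) and the step of a 1.2-fold higher number from compound 1 to compound 3 (0.08 log units; within the scatter) both lie within the scatter, so the three compounds cannot be put in any order. Among these compounds, the earlier pair showed only that a cyano group at this position left the number within the scatter of hydrogen, whereas the position has now carried three different substituents with no change beyond the scatter, and fluoro can be exchanged for either hydrogen or cyano with the same outcome. No measurement is available that would explain this result.

As far as these compounds go, it remains open whether a quite different group at this position, such as an amine, a carboxylic acid or a longer alkyl chain, would also stay within the scatter. From the compounds shown here alone, it is equally open whether fluoro or cyano on another carbon of this ring would behave the same way.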